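The source may report more compounds than this note shows. Statements on the series, on what has been measured and on what is new or still open speak of the compounds shown alone.

Compound 2 `O=C1/C(=C/c2cccc(Cl)c2)Cc2cc(O)ccc21` gives the lowest number of the three measured in an assay on isolated protein for inhibition of Amine oxidase [flavin-containing] B (Homo sapiens), read by fluorescence and spectrophotometry, with a stated time of 20 min (a lower number here means a stronger inhibitor, a higher number a weaker inhibitor), at 30 nM. Compound 1 `O=C1/C(=C/c2cccc(F)c2)Cc2cc(O)ccc21` gives 84 nM in this assay, so that a 2.8-fold lower number from compound 1 to compound 2 (0.45 log units; beyond the scatter). Compound 3 `N#Cc1cccc(/C=C2\Cc3cc(O)ccc3C2=O)c1` gives 130 nM in this assay, and a 4.3-fold higher number from compound 2 to compound 3 (0.64 log units; beyond the scatter). Compound 4 `O=C1/C(=C/c2ccc(Cl)c(Cl)c2)Cc2cc(O)ccc21` differs from compound 2 by chloro in place of hydrogen on an aromatic carbon. Among the measured compounds shown here, no measured step exchanges hydrogen for chloro; the steps seen so far, a 2.8-fold lower number from compound 1 to compound 2 (0.45 log units; beyond the scatter) and a 1.5-fold higher number from compound 1 to compound 3 (0.19 log units; within the scatter), swap one group for another at a single position, and chloro gave the lowest number there. For compound 4 the expected step is therefore small, a 1.2-fold lower number from compound 2 to compound 4 (0.08 log units; within the scatter), within or near the scatter. Compound 4 is expected to give 25 nM in this assay, with a range of 9 nM to 70 nM.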

Compound 4, half-maximal inhibitory concentration: 14 nM
Compound 4: the middle estimate sits 1.8-fold (0.25 log units) above what was measured; the measured number falls inside the stated range.
By their numbers in this assay, from the lowest: compound 4; then compound 2; then compounds 1 and 3 (each within the scatter of the next).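

Chloro in place of hydrogen, ortho to a chloro group and para to a large group, gives a 2.1-fold lower number from compound 2 to compound 4 (0.33 log units; beyond the scatter) in this assay and is a modest change. Unlike the earlier steps, which swap one group for another, this one adds a group to a carbon that carried only hydrogen. This aromatic carbon therefore accepts a chloro group without any rise in the number.

From the compounds shown here alone, whether a methoxy group, an amine or a carboxylic acid at this carbon would lower the number too remains open, as does whether the gain persists with fluoro or nitrile at the other ring position. No measurement at hand explains the step.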